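A few compounds are considered here, and "the series" means these few. Any claim that something is new, unique, unknown or untested is made for them only; others in the source may bear on it.

Going by the values given here, compound 1 `Cc1cn([C@H]2C[C@H](O)[C@@H](CO)O2)c(=O)n(/C=C/C=O)c1=O` gives the lower of the two numbers measured so far in a functional assay on HeLa cells (Homo sapiens) for inhibition (on this read-out higher numbers stand for weaker inhibition and lower numbers for stronger inhibition), at 20000 nM. Among the compounds with values here, its only measured neighbour is compound 2 `O=C/C=C/n1c(=O)c(I)cn([C@H]2C[C@H](O)[C@@H](CO)O2)c1=O`, which in this assay gives 80000 nM; that step, a 4.0-fold higher number from compound 1 to compound 2 (0.60 log units; beyond the scatter), concerns the aromatic ring and not the sugar. Compound 3 `Cc1cn([C@@H]2O[C@H](CO)[C@@H](O)[C@@H]2O)c(=O)n(/C=C/C=O)c1=O` differs from compound 1 by hydroxy in place of hydrogen on a saturated ring carbon. Within the data shown here, no measured step touches this saturated ring, so the forecast rests on compound 1 alone, and the change is expected to stay small, a 1.5-fold higher number from compound 1 to compound 3 (0.18 log units; within the scatter). Compound 3 is therefore estimated at 30000 nM in this assay, within 8000 nM to 120000 nM.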

Compound 3, half-maximal inhibitory concentration: 100000 nM
Beside the measured number, compound 3's estimate is 3.3-fold (0.52 log units) below it, within the range that was stated.
By their numbers in this assay, from the lowest: compound 1; then compounds 2 and 3 (each within the scatter of the next).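

On this saturated ring carbon, hydroxy in place of hydrogen weakens inhibition in this assay, with a 5.0-fold higher number from compound 1 to compound 3 (0.70 log units; beyond the scatter). Going by these compounds alone, this is the first measured sign that the five-membered non-aromatic ring, and not only the aromatic ring, affects the read-out. The data at hand offer no explanation for this step. The compounds shown leave open whether fluoro, methoxy or an amine on this same ring carbon would also weaken inhibition. They also leave open whether hydroxy would have a similar effect with iodo in place of methyl on the aromatic carbon.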